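Sulfoximine Gives Way to Acetyl on the Aryl Ring

The source may hold more compounds than are shown below. What is called first, only, known or untested is meant among the compounds shown, and "the series" means these compounds.

Of the compounds shown here, two built on a shared core have been measured. In an assay on cells (Hepatocyte) for inhibition of glucokinase regulatory protein (Mus musculus), with stated times of 20 min and 40 min (on this read-out higher numbers stand for an effect only at larger amounts of compound and lower numbers for an effect already at smaller amounts), compound 1 `CC#C[C@H]1CN(S(=O)(=O)c2ccc(N)nc2)CCN1c1ccc(C(O)(COC)C(F)(F)F)cc1` gives 202 nM. In this assay, among the compounds with values here, compound 2 `CC#C[C@H]1CN(S(=O)(=O)c2ccc(N)nc2)CCN1c1ccc(S(C)(=N)=O)cc1` gives 704 nM, the higher of the two numbers, the one other compound being compound 1 at a 3.5-fold higher number from compound 1 to compound 2 (0.54 log units; beyond the scatter).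

Compound 3 `CC#C[C@H]1CN(S(=O)(=O)c2ccc(N)nc2)CCN1c1ccc(C(C)=O)cc1` differs from compound 2 at the same aromatic carbon: a group of 3 heavy atoms (2 carbon, 1 oxygen; no ring) in place of a group of 4 heavy atoms (1 carbon, 1 nitrogen, 1 oxygen, 1 sulfur; no ring), on an aromatic carbon. The acetyl group enters on an aromatic carbon of a six-membered aromatic ring of carbon only, para to a large group, and carries no hydrogen-bond donor where the departing group had one.

Within the data shown here, the only measured step that bears on this position is a 3.5-fold higher number from compound 1 to compound 2 (0.54 log units; beyond the scatter), a modest change for a change of group at this carbon. A step of similar or smaller size is therefore expected in this assay, with direction uncertain but leaning toward a higher number. For compound 3 the estimate is 1300 nM, within a range from 400 nM to 4000 nM. This expectation corresponds to a 1.8-fold higher number from compound 2 to compound 3 (0.27 log units; within the scatter).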

Compound 3, half-maximal effective concentration: > 12500 nM
Compound 3 gave a limit, no number; the forecaster's own chance of this, stated with the estimate: 10%; middle value at least 9.6-fold (0.98 log units) away from the limit.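

In this assay, within the data shown here, compound 3 stands at a limit of the assay, not at a number: the limit of > 12500 nM in this assay, at which 1 of the 3 values shown sits. Acetyl at this aromatic carbon gives an at least 17-fold higher number from compound 2 to compound 3 (1.24 log units; beyond the scatter), and measured against the larger group of the other compound it gives an at least 61-fold higher number from compound 1 to compound 3 (1.79 log units; beyond the scatter); both steps are large, whereas the only earlier step at this carbon, a 3.5-fold higher number from compound 1 to compound 2 (0.54 log units; beyond the scatter), was modest. The position therefore proved far more sensitive to the choice of group than that single step had shown, and the change to acetyl, which leaves the shared core untouched and takes away the one hydrogen-bond donor counted on the departing group of compound 2, is enough on its own to carry the number up to the limit.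

The three compounds cannot tell whether the loss of that donor accounts for the step, since acetyl differs from the departing group in its atoms and double bonds as well. From the compounds shown here alone, a primary amide or a hydroxymethyl group at the same carbon would bear on that question, and how far either would stand from compound 2 remains open.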